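From compound 3 to compound 4: cyano to methyl

A few compounds are considered here, and "the series" means these few. Any claim that something is new, unique, unknown or untested is made for them only; others in the source may bear on it.

compound 1 `N#Cc1ccc(-c2ccc(Cn3cccc(O)c3=O)cc2)cc1`: > 10 ug/mL
compound 2 `N#Cc1cccc(-c2ccc(Cn3cccc(O)c3=O)cc2)c1`: > 10 ug/mL
compound 3 `N#Cc1cccc(-c2ccc(Cn3cccc(O)c3=S)cc2)c1`: > 10 ug/mL

All three entries are limits, not numbers. In an ADME assay on THP-1 cells (Homo sapiens) for cytotoxicity, read by resazurin assay, with a stated time of 48 h (on this read-out lower numbers stand for stronger inhibition and higher numbers for weaker inhibition), compound 3 stands at a limit of > 10 ug/mL. Going by the values given here, the series so far offers only (the limit of > 10 ug/mL in this assay, at which 3 of the 3 values shown sit).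

Compound 4 `Cc1cccc(-c2ccc(Cn3cccc(O)c3=S)cc2)c1` has methyl in place of cyano on an aromatic carbon, meta to a large group: methyl in place of cyano on an aromatic carbon. Among the compounds with values here, no measured pair shows this change, so its size can only be estimated. Starting from compound 3 at its limit of > 10 ug/mL, no step beyond the scatter is expected in this assay, in either direction. The expected change is a step that the limit leaves unreadable from compound 3 to compound 4. A further report as a limit is the likeliest outcome. For compound 4 the estimate is 15 ug/mL, with an expected range from 5 ug/mL to 40 ug/mL.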

Compound 4, half-maximal inhibitory concentration: > 10 ug/mL
Compound 4 ended at the assay's limit (the forecaster's own chance of this, stated with the estimate: 70%); the middle value lies beyond the limit too.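

No step can be read from compound 3 to compound 4 in this assay, because both are reported only as limits: the limit of > 10 ug/mL in this assay, at which 4 of the 4 values shown sit.

The compounds shown leave open where any of the four would fall beyond that limit, and so whether methyl in place of cyano changes the read-out at all.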